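The source may report more compounds than this note shows. Statements on the series, on what has been measured and on what is new or still open speak of the compounds shown alone.

Working notes on the series. Among the compounds with values here, in an assay on CHO cells for displacement of a labelled ligand from adenosine receptor A1 (Homo sapiens) (on this read-out lower numbers stand for stronger inhibition and higher numbers for weaker inhibition), compound 2 `CCOC(=O)c1cnc(NCCOC)n2nc(-c3ccco3)nc12` gives 2270 nM, the lowest of the two numbers so far; compound 1 `CCOC(=O)c1cnc(N2CCCCC2)n2nc(-c3ccco3)nc12` gives 8860 nM. Within the data shown here, the one measured step, a 3.9-fold lower number from compound 1 to compound 2 (0.59 log units; beyond the scatter), is the only comparison that bears on the next change. Compound 3 `CCOC(=O)c1cnc(N(C)C)n2nc(-c3ccco3)nc12` differs from compound 2 by dimethylamino in place of (2-methoxyethyl)amino on an aromatic carbon. Among the measured compounds shown here, since the only measured change at this carbon moved the number by a 3.9-fold lower number from compound 1 to compound 2 (0.59 log units; beyond the scatter) when a tertiary amine gave way to the (2-methoxyethyl)amino group, a return to a tertiary amine is expected to cost part of that, with a step of about a 2.2-fold higher number from compound 2 to compound 3 (0.34 log units; beyond the scatter). Compound 3 is therefore expected near 5000 nM, within 1800 nM to 14000 nM.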

Compound 3, inhibition constant: 13400 nM
Estimate against measurement, compound 3: 2.7-fold (0.43 log units) below; the range from low to high includes it.
By their numbers in this assay, from the lowest: compound 2; then compounds 1 and 3 (each within the scatter of the next).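

Dimethylamino in place of (2-methoxyethyl)amino gives a 5.9-fold higher number from compound 2 to compound 3 (0.77 log units; beyond the scatter), whereas dimethylamino in place of piperidin-1-yl gives a 1.5-fold higher number from compound 1 to compound 3 (0.18 log units; within the scatter), so ring and open-chain tertiary amines are not separated at this carbon. Of the three compounds, only compound 2 stands apart, and it alone has a hydrogen-bond donor in this group. No measurement here gives a reason for these steps. The compounds shown leave open whether the gain follows the amine hydrogen or the ether oxygen, which a simple ethylamino group or an N-methyl-(2-methoxyethyl)amino group would separate.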